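The source may hold more compounds than are shown below. What is called first, only, known or untested is meant among the compounds shown, and "the series" means these compounds.

Measured compounds:
Compound 1 `CC/C(=C(/c1ccc(/C=C/C(=O)O)cc1)c1cnc2[nH]ncc2c1)c1ccccc1`: 302 nM
Compound 2 `CC/C(=C(/c1ccc(/C=C/C(=O)O)cc1)c1ccc2[nH]ncc2c1F)c1ccccc1`: 3 nM
Compound 3 `CC/C(=C(/c1ccc(/C=C/C(=O)O)cc1)c1cc2cn[nH]c2cc1F)c1ccccc1`: 47 nM

All three were tested in a functional assay on MCF7 cells (Homo sapiens) for cytotoxicity, read by CellTiter-Glo, with a stated time of 5 days; on this read-out lower numbers stand for stronger inhibition and higher numbers for weaker inhibition. Compound 3 holds the second highest number of the three: compound 1 sits above it, as a 6.4-fold lower number from compound 1 to compound 3 (0.81 log units; beyond the scatter) shows, while compound 2 sits far below it, as a 16-fold higher number from compound 2 to compound 3 (1.19 log units; beyond the scatter) shows. For the measured compounds named here, the only change between compound 2 and compound 3 is where the fluorine sits on the indazole, and that alone moved the number by a large step.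

Compound 4 `CC/C(=C(/c1ccc(/C=C/C(=O)O)cc1)c1cc(F)c2[nH]ncc2c1)c1ccccc1` has not yet been measured. It differs from compound 3 by 7-fluoro-1H-indazol-5-yl in place of 6-fluoro-1H-indazol-5-yl on a double-bonded chain carbon bound to an aromatic carbon and a double-bonded chain carbon. So once more the fluorine is moved around the same ring system. The step of a 16-fold higher number from compound 2 to compound 3 (1.19 log units; beyond the scatter) bears on this most directly and shows that such a move can shift the number a great deal in either direction. Going by the values given here, with only one such comparison there is no firm basis for saying which way. Compound 4 is therefore expected to land between the two fluorinated compounds, with a step of a 1.9-fold lower number from compound 3 to compound 4 (0.27 log units; within the scatter), at an estimated 25 nM, in the range 5 nM to 150 nM.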

Compound 4, half-maximal inhibitory concentration: 7.5 nM
For compound 4 the middle estimate is 3.3-fold (0.52 log units) above the measured one; the range from low to high includes it.
By their numbers in this assay, from the lowest: compound 2; then compound 4; then compound 3; then compound 1.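

In this assay, the fluorine's place on the indazole matters again: 7-fluoro-1H-indazol-5-yl in place of 6-fluoro-1H-indazol-5-yl gives a 6.3-fold lower number from compound 3 to compound 4 (0.80 log units; beyond the scatter). The 4-fluoro group still holds the lowest number, with a 2.5-fold higher number from compound 2 to compound 4 (0.40 log units; beyond the scatter), so the three placements now rank from lowest number as 4-fluoro, 7-fluoro, 6-fluoro. The new compound also stays well below the fluorine-free group of compound 1, with a 40-fold lower number from compound 1 to compound 4 (1.60 log units; beyond the scatter), so all three fluorinated compounds now lie below it.

Why the fluorine's place changes the number stays open, as nothing measured here speaks to it. Also open, going by these compounds, is whether chlorine or a methyl group in place of the fluorine would follow the same order, and where the plain 1H-indazol-5-yl group would fall.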